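The source may report more compounds than this note shows. Statements on the series, on what has been measured and on what is new or still open speak of the compounds shown alone.

Among the compounds with values here, in a functional assay on MDA-MB-435 cells (Homo sapiens) for cytotoxicity, read by MTT assay, with a stated time of 72 h (on this read-out higher numbers stand for weaker inhibition and lower numbers for stronger inhibition), compound 2 (`O=C(NCc1ccc(F)cc1)c1nc(Br)c2cccnc2c1N1CCNCC1`) gives 8000 nM, the only true number so far. Compound 1 (`C[C@H](Nc1c(C(=O)NCc2ccc(F)cc2)nc(Br)c2cccnc12)c1ccccc1`) stands at a limit of this assay, > 20000 nM. Compound 3 (`O=C(NCc1ccc(F)cc1)c1nc(Br)c2cccnc2c1NCc1ccccc1`) changes compound 2 at one place on the shared core: benzylamino in place of piperazin-1-yl on an aromatic carbon. This puts benzylamino in place of piperazin-1-yl on an aromatic carbon, para to a bromo group. Within the data shown here, the one measured step bearing on this is an at least 2.5-fold lower number from compound 1 to compound 2 (0.39 log units; beyond the scatter), where piperazin-1-yl replaced (1-phenylethyl)amino at that carbon. The new change runs roughly against that step, so a modest move to a higher number is expected in this assay, possibly as far as the limit. Compound 3 is estimated at 15000 nM, with an expected range of 5000 nM to 40000 nM. That expectation amounts to a 1.9-fold higher number from compound 2 to compound 3 (0.27 log units; within the scatter).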

Compound 3, half-maximal inhibitory concentration: > 20000 nM
Compound 3: a limit, no number; the forecaster's own chance of this, stated with the estimate: 40%; middle value at least 1.3-fold (0.12 log units) from the limit.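

In this series, the gain at the aromatic carbon para to a bromo group no longer rests on a single comparison. Piperazin-1-yl now stands against two replacements: besides (1-phenylethyl)amino, benzylamino also gives an at least 2.5-fold higher number from compound 2 to compound 3 (0.39 log units; beyond the scatter) in this assay. Hydrogen in place of methyl on the saturated chain carbon leaves no readable step between compound 1 and compound 3, since both values are limits and not numbers: the limit of > 20000 nM in this assay, at which 2 of the 3 values shown sit.

The compounds shown do not tell whether the lower number of compound 2 goes with the second ring nitrogen of piperazin-1-yl or with the saturated ring as a whole; a morpholine or a piperidine at this carbon would separate the two. On these data alone, how far compound 1 and compound 3 lie past the limit also stays open.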